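The source may report more compounds than this note shows. Statements on the series, on what has been measured and on what is new or still open speak of the compounds shown alone.

Within the data shown here, compound 2, with the structure `Cc1c(C)c2c(c(C)c1O)CCC(C)(C(=O)N1CCN(c3ccccn3)CC1)O2`, holds the lowest number of the two compounds measured so far: in a functional assay (brain) for inhibition, with Rattus norvegicus as the target (a higher number here means a weaker inhibitor, a lower number a stronger inhibitor), compound 2 gives 1000 nM, whereas compound 1, `CC(=O)Oc1c(C)c(C)c2c(c1C)CCC(C)(C(=O)N1CCN(c3cc(N4CCCC4)nc(N4CCCC4)n3)CC1)O2`, gives 17000 nM in this assay, a gap beyond the usual scatter. Compound 3, `Cc1c(C)c2c(c(C)c1O)CCC(C)(C(=O)N1CCNCC1)O2`, has not yet been measured; it differs from compound 2 by hydrogen in place of pyridin-2-yl on an amine nitrogen in a ring. Among the measured compounds shown here, no step between measured compounds shows the effect of such a change, so the size is uncertain; a moderate shift toward a higher number is expected, a 3.0-fold higher number from compound 2 to compound 3 (0.48 log units; beyond the scatter). Compound 3 is therefore estimated at 3000 nM in this assay, within a range from 1000 nM to 12000 nM.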

Compound 3, half-maximal inhibitory concentration: 10000 nM
The estimate for compound 3 lay 3.3-fold (0.52 log units) below the measured number; the range from low to high includes it.
By their numbers in this assay, from the lowest: compound 2; then compounds 3 and 1 (each within the scatter of the next).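

Replacing pyridin-2-yl with hydrogen on the amine nitrogen in the ring gives a 10-fold higher number from compound 2 to compound 3 (1.00 log units; beyond the scatter) in this assay. Among these compounds, this is the first single change that can be read, and it shows that the aromatic group at this nitrogen matters in this assay, with the free ring amine of compound 3 the weaker inhibitor. The compounds shown give no independent data on what lies behind this step.

On these data alone, whether a phenyl ring, a benzyl group or a methyl group on this nitrogen would match pyridin-2-yl remains open.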